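The compounds below may be only part of what the source reports. "The series", "measured", "known", "first", "only" and "open" are said of these compounds alone.

Of the compounds shown here, three have been tested in an ADME assay on IMR-90 cells (Homo sapiens) for antiproliferative activity, read by MTT assay, with a stated time of 72 h (a higher number here means a weaker inhibitor, a lower number a stronger inhibitor), and none of them gives a true number. Compound 1 `O=C1C=C(N2CCN(c3ccccc3Cl)CC2)C(=O)c2ccccc21` is reported only as a limit, > 50000 nM. Compound 2 `O=C1C=C(N2CCN(c3ccccc3)CC2)C(=O)c2c(O)ccc(O)c21` is likewise reported only as a limit, > 50000 nM. Compound 3 `O=C1C=C(N2CCC(c3ccccc3)CC2)C(=O)c2c(O)cccc21` is also reported only as a limit, > 50000 nM. The whole record therefore amounts to the limit of > 50000 nM in this assay, at which 3 of the 3 values shown sit, and compound 3 stands with the other two, with nothing to rank them.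

Compound 4 `O=C1C=C(N2CCC(c3ccc(Cl)cc3)CC2)C(=O)c2c(O)cccc21` differs from compound 3 in one place, with chloro in place of hydrogen on an aromatic carbon, para to a large group, so that phenyl becomes 4-chlorophenyl: chloro in place of hydrogen on an aromatic carbon. Going by the values given here, no measured pair shows what a change of this kind does in this assay.

Compound 3 is the closest guide for an expectation, and its limit is > 50000 nM. The expected step is a number no higher from compound 3 to compound 4 (the limit leaves the size open), estimated to stay within the usual scatter and to have no clear direction. Compound 4 may well be reported only as a limit again. As a number, compound 4 is estimated at 50000 nM, with an expected range from 18000 nM to 100000 nM.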

Compound 4, half-maximal inhibitory concentration: > 50000 nM
Compound 4: no number, only a limit; the forecaster's own chance of this, stated with the estimate: 65%; the middle value sits exactly at the limit.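

Going by these compounds alone, compound 3 and compound 4 are both reported only as limits, and no step between them can be read in this assay. The whole record now rests on a single limit: the limit of > 50000 nM in this assay, at which 4 of the 4 values shown sit. The compounds shown leave open what true number any of them would give, and what chloro in place of hydrogen on an aromatic carbon does in this assay.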